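Phenyl in place of iodo on the thiourea aryl group

A few compounds are considered here, and "the series" means these few. Any claim that something is new, unique, unknown or untested is made for them only; others in the source may bear on it.

Compound 1 `NC(=O)c1c(NC(=O)c2ccccc2Cl)sc2c1CCN(C(=S)Nc1ccccc1)C2` gives 46700 nM in a functional assay on HeLa cells (Homo sapiens) for antiproliferative activity, with a stated time of 24 h; on this read-out higher numbers stand for weaker inhibition and lower numbers for stronger inhibition. Compound 2 `NC(=O)c1c(NC(=O)c2ccccc2Cl)sc2c1CCN(C(=S)Nc1ccccc1I)C2` gives 29000 nM in this assay. The step of a 1.6-fold lower number from compound 1 to compound 2 (0.21 log units; within the scatter) is within the scatter. Compound 2 thus sits at one end of the two numbers shown, with compound 1 as its only neighbour, and the two numbers cannot be told apart.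

Compound 3 `NC(=O)c1c(NC(=O)c2ccccc2Cl)sc2c1CCN(C(=S)Nc1ccccc1-c1ccccc1)C2` carries phenyl in place of iodo on an aromatic carbon. Among the measured compounds shown here, the only step that bears on this change is a 1.6-fold lower number from compound 1 to compound 2 (0.21 log units; within the scatter), which placed a substituent at the same position and stayed within the scatter. For the measured compounds named here, no measured step here goes beyond the scatter, so nothing in these two compounds points to a step of real size for compound 3 in this assay. Compound 3 is therefore expected at 25000 nM, with a range from 8000 nM to 80000 nM. This amounts to an expected step of a 1.2-fold lower number from compound 2 to compound 3 (0.06 log units; within the scatter), which is not expected to exceed the scatter.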

Compound 3, half-maximal inhibitory concentration: 24000 nM
The estimate for compound 3 lay 1.0-fold (0.02 log units) above the measured number; measured number inside the range.
By their numbers in this assay, from the lowest: compounds 3, 2 and 1 (each within the scatter of the next).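

In this assay, phenyl in place of iodo brings in six heavy atoms and a six-membered aromatic ring of carbon only, ortho to a large group, and gives a 1.2-fold lower number from compound 2 to compound 3 (0.08 log units; within the scatter). Phenyl in place of hydrogen at the same carbon gives a 1.9-fold lower number from compound 1 to compound 3 (0.29 log units; within the scatter), so hydrogen, iodo and phenyl cannot be told apart here, even with a whole added ring at this place. No supporting data bear on this result.

Still open, as far as these compounds go, is whether an amine, a carboxylic acid or a longer alkyl chain at this place would give a step beyond the scatter. The compounds shown also leave open whether any change on the thiourea aryl group can move the number by more than the scatter.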